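Quinoline carboxamide series: secondary to tertiary amide

A few compounds are considered here, and "the series" means these few. Any claim that something is new, unique, unknown or untested is made for them only; others in the source may bear on it.

Values in an assay on brain with Translocator protein (Rattus norvegicus) as the target; on this read-out higher numbers stand for weaker inhibition and lower numbers for stronger inhibition:
- compound 1 `Cc1nc2ccccc2c(-c2ccccc2)c1C(=O)N(C)c1ccccc1`: > 10000 nM, a limit of the assay, not a number
- compound 2 `CCOC(=O)c1c(Cl)nc2ccccc2c1-c1ccccc1`: 3700 nM
- compound 3 `CCCNC(=O)c1c(CN(CC)Cc2ccccc2)nc2ccccc2c1-c1ccccc1`: 872 nM

Compound 1 sits at the assay limit, as noted in the limit of > 10000 nM in this assay, at which 1 of the 3 values shown sits. Among the measured compounds shown here, of the two compounds with numbers, compound 3 gives the lower value and compound 2 the higher, and the gap between the two lies beyond the usual scatter; with only two numbers, no ordering beyond this pair can be claimed.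

The next compound, compound 4 `CCCN(CCC)C(=O)c1c(CN(CC)Cc2ccccc2)nc2ccccc2c1-c1ccccc1`, keeps the shared core of compound 3 and changes only the amide: propyl in place of hydrogen on an amide-type nitrogen, in words, propyl in place of hydrogen on an amide-type nitrogen, so that propylcarbamoyl becomes dipropylcarbamoyl. For the measured compounds named here, no measured pair in this set differs in one place, so no step is recorded to lean on. The expectation is nonetheless a move toward stronger inhibition in this assay, that is a lower number, of moderate size and probably beyond the scatter, since compound 3 already gives the lower of the two numbers with 872 nM. The expected step is a 5.8-fold lower number from compound 3 to compound 4 (0.76 log units; beyond the scatter). For compound 4 the estimate in this assay is 150 nM, within a range from 20 nM to 1500 nM.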

Compound 4, half-maximal inhibitory concentration: 456 nM
For compound 4 the middle estimate is 3.0-fold (0.48 log units) below the measured one; low and high end bracket the measured number.
By their numbers in this assay, from the lowest: compounds 4 and 3 (each within the scatter of the next); then compound 2. At a limit, above all of these: compound 1.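

In this assay, among the compounds shown here, the first step that changes one place only is a 1.9-fold lower number from compound 3 to compound 4 (0.28 log units; within the scatter) and so gives no direction for propyl in place of hydrogen on the amide-type nitrogen. The amide hydrogen is thus not shown to be required at this level of binding: compound 4 lacks it, yet its number cannot be told apart from that of compound 3, and the nitrogen carries the added propyl without a change beyond the scatter. Nothing measured here bears on why this step is small, and no cause can be assigned to it.

Still open, on these data alone, is whether a longer chain such as hexyl, a cyclic amide such as the piperidine amide, or a carboxylic acid in place of the amide would separate from compound 3 and compound 4. Also open is how much the benzyl and ethyl groups on the amine of the shared side chain contribute, as no pair shown varies them alone.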